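Swapping Nitro for Fluoro on a Sulfonyl Compound

The compounds below may be only part of what the source reports. "The series", "measured", "known", "first", "only" and "open" are said of these compounds alone.

Compound 1 `Cc1nc([N+](=O)[O-])cn1CC(=O)NCc1ccccc1` gives 77600 nM
Compound 2 `Cc1nc([N+](=O)[O-])cn1S(=O)(=O)c1ccc([N+](=O)[O-])cc1` gives 611000 nM
Compound 3 `Cc1nc([N+](=O)[O-])cn1CC(=O)Nc1ccccc1` gives 1140000 nM

In an ADME assay on MDCK cells (Canis lupus familiaris) for cytotoxicity, read by MTT assay, with a stated time of 72 h (on this read-out higher numbers stand for lower toxicity in this test and lower numbers for higher toxicity in this test), compound 2 at 611000 nM lies within the usual scatter of compound 3 at 1140000 nM and compound 1 at 77600 nM stands clearly lower than both.

Compound 4 `Cc1nc([N+](=O)[O-])cn1S(=O)(=O)c1ccc(F)cc1` keeps all of compound 2 except one group. It carries fluoro in place of nitro on an aromatic carbon, para to a large group fluoro in place of nitro on an aromatic carbon and nothing else changes.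

Among the compounds with values here, no two measured compounds here differ in one place only, so the data offer no direct guide to this swap. The expectation therefore rests on compound 2 at 611000 nM alone, and the wide spread of the three values calls for a broad range. The estimated change is a 1.4-fold lower number from compound 2 to compound 4 (0.13 log units; within the scatter) and no step beyond the scatter is expected in this assay here. The estimate for compound 4 is 450000 nM within an expected range of 150000 nM to 1500000 nM for this compound.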

Compound 4, half-maximal cytotoxic concentration: 813000 nM
Compound 4: the middle estimate sits 1.8-fold (0.26 log units) below what was measured; low and high end bracket the measured number.
By their numbers in this assay, from the lowest: compound 1; then compounds 2, 4 and 3 (each within the scatter of the next).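

In this assay, putting fluoro in place of nitro on an aromatic carbon, para to a large group, gives a 1.3-fold higher number from compound 2 to compound 4 (0.12 log units; within the scatter). Within the data shown here, this is the first comparison in the set between two compounds that differ in one place only, so it tests this site directly. Here, the three heavy atoms of the nitro group give way to the single atom of fluoro, and the read-out of this cell test cannot be told apart from that of compound 2. Nothing measured here explains why the two compounds read alike.

On these data alone, whether an amine or a carboxylic acid at the same place would also leave the read-out unchanged remains open. The same question stands for a chloro or a methyl group, and for a ring carrying no group there at all.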